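This account rests on a few compounds, and the source may have more. Where it says the series, first, only, none or still open, it means among the compounds named here.

Compound 1 `C=C1C(=O)[C@]23C[C@@]1(O)CC[C@H]2c1ccc(O)c(C)c1[C@@H]3Cn1cc(-c2ccc(C(F)(F)F)cc2)nn1` — 1440 nM
Compound 2 `C=C1C(=O)[C@]23C[C@@]1(O)CC[C@H]2c1ccc(OS(=O)(=O)c2ccc(C)cc2)c(C)c1[C@@H]3Cn1cc(-c2ccc(F)cc2)nn1` — 4280 nM

In a functional assay on SMMC-7721 cells (Homo sapiens) for cytotoxicity, read by MTT assay, with a stated time of 4 days (on this read-out lower numbers stand for stronger inhibition and higher numbers for weaker inhibition), compound 1 stands lowest of the two numbers; compound 2 sits higher, beyond the scatter. For the measured compounds named here, no measured pair in this set differs in one place only, so no step size is known from these data. Compound 3 `C=C1C(=O)[C@]23C[C@@]1(O)CC[C@H]2c1ccc(O)c(C)c1[C@@H]3Cn1cc(-c2ccccn2)nn1` keeps the core of compound 1 with pyridin-2-yl in place of 4-(trifluoromethyl)phenyl on an aromatic carbon. A small step toward weaker inhibition is expected, a 1.7-fold higher number from compound 1 to compound 3 (0.22 log units; within the scatter), likely within the scatter. Compound 3 is estimated at 2400 nM in this assay, with a range from 900 nM to 7000 nM.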

Compound 3, half-maximal inhibitory concentration: 1270 nM
For compound 3 the middle estimate is 1.9-fold (0.28 log units) above the measured one; the measured number falls inside the stated range.
By their numbers in this assay, from the lowest: compounds 3 and 1 (each within the scatter of the next); then compound 2.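

In this assay the step at this position is a 1.1-fold lower number from compound 1 to compound 3 (0.05 log units; within the scatter) and so stays within the scatter. This aromatic carbon of the five-membered aromatic ring with 3 nitrogen therefore accepts pyridin-2-yl in place of 4-(trifluoromethyl)phenyl without a readable change, even though the trifluoromethyl group leaves and a ring nitrogen enters. Nothing available explains this flat step.

Still open, as far as these compounds go, is whether a carboxylic acid, an aliphatic amine or a longer alkyl chain on this carbon would leave the number equally unmoved.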